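Allyl to ethyl on the ester of compound 2

This account rests on a few compounds, and the source may have more. Where it says the series, first, only, none or still open, it means among the compounds named here.

In a functional assay on BXPC-3 cells (Homo sapiens) for antiproliferative activity, read by sulforhodamine B assay, with a stated time of 72 h (a higher number here means a weaker inhibitor, a lower number a stronger inhibitor), compound 1 `C=CCOC(=O)C1=C2C(=NC1=O)c1cccc3cccc2c13` gives 4800 nM. Compound 2 `C=CCOC(=O)C1=C2C(=NC1=O)c1cccc3c(SCCC)ccc2c13`, with propylsulfanyl in place of hydrogen on an aromatic carbon, gives 12900 nM, which is a 2.7-fold higher number from compound 1 to compound 2 (0.43 log units; beyond the scatter). Compound 3 `CCCSC(=O)COC(=O)C1=C2C(=NC1=O)c1cccc3cccc2c13` gives 10100 nM, which is a 2.1-fold higher number from compound 1 to compound 3 (0.32 log units; beyond the scatter). Compound 2 and compound 3 lie within the scatter of each other, and only compound 1 stands apart from compound 2.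

Compound 4 `CCCSc1ccc2c3c(cccc13)C1=NC(=O)C(C(=O)OCC)=C12` keeps the propylsulfanyl and differs from compound 2 in the ester: methyl in place of vinyl on a saturated chain carbon bound to an oxygen next to a carbonyl group. This is methyl in place of vinyl, or allyloxycarbonyl to ethoxycarbonyl. Among the compounds with values here, no measured step makes this exact change. The closest, at the same place, is the modest 2.1-fold higher number from compound 1 to compound 3 (0.32 log units; beyond the scatter), although a different group enters there. The step of a 2.7-fold higher number from compound 1 to compound 2 (0.43 log units; beyond the scatter) lies elsewhere on the molecule and does not bear directly on the change. No step beyond the scatter is therefore expected in this assay, and the expected step is a 1.1-fold lower number from compound 2 to compound 4 (0.03 log units; within the scatter). For compound 4 the estimate is 12000 nM, with an expected range of 6000 nM to 24000 nM.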

Compound 4, half-maximal inhibitory concentration: 5800 nM
Compound 4: the middle estimate sits 2.1-fold (0.32 log units) above what was measured; measured number outside the range, below it.
By their numbers in this assay, from the lowest: compounds 1, 4, 3 and 2 (each within the scatter of the next, the first and the last beyond it).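

The ester place still responds in this assay with the propylsulfanyl present: allyl to ethyl gives a 2.2-fold lower number from compound 2 to compound 4 (0.35 log units; beyond the scatter) and so brings the number down, with the double bond outside aromatic rings leaving along with the vinyl. Within the data shown here, the only change read earlier at this place, a 2.1-fold higher number from compound 1 to compound 3 (0.32 log units; beyond the scatter) on the core of compound 1, went the other way, so this place can move the number in either direction, though the two steps have different parents and different entering groups. No measurement shown here gives a reason for the step.

Going by these compounds, whether allyl to ethyl acts the same way on the core of compound 1, with hydrogen in place of propylsulfanyl, remains open. Also open, on these data alone, is how a longer chain such as butyl, or a carboxylic acid, would read at this place.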